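Aryl sulfonamide series: cytotoxicity notes ahead of compound 4

This account rests on a few compounds, and the source may have more. Where it says the series, first, only, none or still open, it means among the compounds named here.

Compound 1 `CC1CCN(C2CCN(S(=O)(=O)c3ccc(F)cc3F)CC2)CC1` gives > 5000 nM in an ADME assay on HCT-116 cells (Homo sapiens) for cytotoxicity, read by CellTiter-Glo, with a stated time of 72 h (a higher number here means a weaker inhibitor, a lower number a stronger inhibitor), a limit of the assay.
Compound 2 `CC1CCN(C2CCN(S(=O)(=O)c3cccnc3Cl)CC2)CC1` gives > 10000 nM in this assay, a limit.
Compound 3 `CC1CCN(C2CCN(S(=O)(=O)c3cccc(N)c3)CC2)CC1` gives > 5000 nM in this assay, a limit.

Compound 3 stands at the limit of > 5000 nM in this assay, at which 2 of the 3 values shown sit. The third value sits at the limit of > 10000 nM in this assay, at which 1 of the 3 values shown sits. No value among the three is a number, so the three measured steps, a step that the two limits leave unreadable from compound 1 to compound 2, a step that the two limits leave unreadable from compound 1 to compound 3 and a step that the two limits leave unreadable from compound 2 to compound 3, cannot be sized in either direction.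

Compound 4 `CC1CCN(C2CCN(S(=O)(=O)c3cc(Cl)cc(Cl)c3)CC2)CC1` differs from compound 3 in one place: 3,5-dichlorophenyl in place of 3-aminophenyl on a sulfonyl sulfur. All three measured steps concern exchange of the group on a sulfonyl sulfur, and each of them left the value at a limit; they therefore bear on the step to compound 4 only by suggesting that a further exchange at that sulfur is unlikely to bring the value into the readable range. A step that the limit leaves unreadable from compound 3 to compound 4 is expected, that is, none that can be read beyond the scatter. Compound 4 is estimated at 10000 nM, with a range from 3000 nM to 30000 nM, and most probably reported again only as a limit.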

Compound 4, half-maximal inhibitory concentration: > 5000 nM
Compound 4: a limit, no number; the forecaster's own chance of this, stated with the estimate: 80%; the middle value is on the limit's open side.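

Compound 4 gives > 5000 nM in this assay, a limit. Its steps from compound 1, compound 2 and compound 3 cannot be read, since no value is a number: the limit of > 5000 nM in this assay, at which 3 of the 4 values shown sit.

The compounds shown leave open whether any group on the sulfonyl sulfur gives a readable value.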